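Sulfamoyl series: methoxycarbonyl in place of chloro in compound 2

A few compounds are considered here, and "the series" means these few. Any claim that something is new, unique, unknown or untested is made for them only; others in the source may bear on it.

In a physicochemical assay for acid dissociation, compound 1 (`NS(=O)(=O)c1ccc(S(=O)(=O)CC(O)CO)cc1`) gives 9.35 and compound 3 (`NS(=O)(=O)c1ccc(SCCO)c(F)c1`) gives 9.76 as the two other reference points. Compound 2 (`NS(=O)(=O)c1ccc(SCCCO)c(Cl)c1`) at 9.45 lies within the usual scatter of compound 1, so these two are not separated, while compound 3 stands higher, beyond the scatter.

Among the measured compounds shown here, the next compound is compound 4 (`COC(=O)c1cc(S(N)(=O)=O)ccc1SCCCO`), which has no measurement yet. It carries methoxycarbonyl in place of chloro on an aromatic carbon, ortho to a (3-hydroxypropyl)sulfanyl group and meta to a sulfamoyl group (methoxycarbonyl in place of chloro on an aromatic carbon).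

For the measured compounds named here, no two measured compounds differ in one place only, so the data hold no direct measure of this exchange, and three numbers give only a thin basis for any forecast. The working assumption takes compound 2 at 9.45 as the anchor and expects no step beyond the scatter in this assay, with no firm direction. The expected shift is small (a number 0.05 log units higher from compound 2 to compound 4 (within the scatter)). Compound 4 is expected at 9.5 (estimated range 9.2 to 9.8).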

Compound 4, acid dissociation constant: 9.3
Compound 4: the middle estimate sits 0.20 log units above what was measured; the range from low to high includes it.
By their numbers in this assay, from the lowest: compounds 4, 1 and 2 (each within the scatter of the next); then compound 3.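

On the aromatic carbon ortho to a (3-hydroxypropyl)sulfanyl group and meta to a sulfamoyl group, methoxycarbonyl in place of chloro gives the series its first direct reading of a single exchange: in this assay the reading of a number 0.15 log units lower from compound 2 to compound 4 (within the scatter) leaves the two compounds unseparated. Exchanging 1 heavy atom for 4 heavy atoms, with 2 hydrogen-bond acceptors entering and none leaving, therefore produces no step beyond the scatter at this position, on this chain and in this read-out. Nothing measured here bears on why the number holds, so the result stands as an observation without an explanation.

This is one step on one pair, and it cannot show whether an amine, a carboxylic acid or a nitrile on the same aromatic carbon would also stay within the scatter. It also leaves open whether methoxycarbonyl in place of chloro would read the same with a longer chain in place of the (3-hydroxypropyl)sulfanyl group.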